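Benzamide tail: amino in place of methylpiperidinyl

This account rests on a few compounds, and the source may have more. Where it says the series, first, only, none or still open, it means among the compounds named here.

Measured so far:
compound 1 `COc1cc(OC)c(Cl)c(-c2ccc3c(NC(=O)c4ccc(C5CCN(C)CC5)cc4)n[nH]c3n2)c1Cl` — 8.2 nM
compound 2 `COc1cc(OC)c(Cl)c(-c2ccc3c(NC(=O)c4ccc(N5CCN(C)CC5)cc4Cl)n[nH]c3n2)c1Cl` — 27.6 nM

In a functional assay on NCI-H1581 cells (Homo sapiens) for antiproliferative activity, read by CCK-8 assay, with a stated time of 72 h (on this read-out lower numbers stand for stronger inhibition and higher numbers for weaker inhibition), compound 1 gives 8.2 nM, the lowest of the two numbers. Within the data shown here, compound 2 gives 27.6 nM, a higher number by a margin beyond the usual scatter; compound 2 also differs from compound 1 in more than one place, so no single-point step is known. The unmeasured compound 3 `COc1cc(OC)c(Cl)c(-c2ccc3c(NC(=O)c4ccc(N)cc4)n[nH]c3n2)c1Cl` differs from compound 1 in the benzamide tail alone: amino in place of 1-methylpiperidin-4-yl on an aromatic carbon. A modest step toward a higher number is expected for a 5.5-fold higher number from compound 1 to compound 3 (0.74 log units; beyond the scatter), likely beyond the scatter, since compound 1 with 8.2 nM sits at the low end and the entering group is the smaller one. Compound 3 is therefore estimated at 45 nM, with a range from 10 nM to 250 nM.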

Compound 3, half-maximal inhibitory concentration: 218 nM
Estimate against measurement, compound 3: 4.8-fold (0.69 log units) below, and the stated range covers the measured number.
By their numbers in this assay, from the lowest: compound 1; then compound 2; then compound 3.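

In this assay, among these compounds, the first single-place step is large: a 27-fold higher number from compound 1 to compound 3 (1.42 log units; beyond the scatter). The number at this aromatic carbon, para to a large group, therefore depends strongly on what the benzamide tail carries, which compounds 1 and 2 could not show because they differ in more than one place. The change removes 1-methylpiperidin-4-yl, with its 7 heavy atoms and six-membered non-aromatic ring, and adds amino, with 1 heavy atom and 1 hydrogen-bond donor, and no measurement shown here explains the rise.

On these data alone, it remains open whether the step follows the ring, its nitrogen, its methyl or the new donor. A dimethylamino group or an unmethylated piperidin-4-yl at this carbon would help separate these features.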